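The source may report more compounds than this note shows. Statements on the series, on what has been measured and on what is new or still open speak of the compounds shown alone.

Compound 2 `C#CCN(C)CCCCOc1ccc2c(c1)CCCC2=O`: 72.5 nM; compound 1 `C#CCN(C)CCCCCCOc1ccc2c(c1)CCC2=O`: 129 nM.

Both numbers come from an assay on BTI cells for inhibition of Amine oxidase [flavin-containing] B (Homo sapiens), read by fluorescence and Amplex Red, with a stated time of 15 min; on this read-out higher numbers stand for weaker inhibition and lower numbers for stronger inhibition. Among the compounds with values here, compound 2 holds the smaller of the two numbers, yet its only neighbour, compound 1, sits within the scatter of it, so the pair shows no real separation. Compound 3 `C#CCN(C)CCCCCOc1ccc2c(c1)CCCC2=O` differs from compound 2 by (methyl(propargyl)amino)methyl in place of methyl(propargyl)amino on a saturated chain carbon, four bonds along the chain from an oxygen on an aromatic ring. Within the data shown here, no step between two measured compounds is available to calibrate this change. Given how close compound 2 and compound 1 lie, no step beyond the scatter is expected in this assay. The expected step of a 1.1-fold higher number from compound 2 to compound 3 (0.04 log units; within the scatter) is therefore small. Compound 3 is expected to give 80 nM, in a range from 35 nM to 180 nM.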

Compound 3, half-maximal inhibitory concentration: 46.3 nM
Estimate against measurement, compound 3: 1.7-fold (0.24 log units) above, and the stated range covers the measured number.
By their numbers in this assay, from the lowest: compounds 3, 2 and 1 (each within the scatter of the next, the first and the last beyond it).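

In this assay, (methyl(propargyl)amino)methyl in place of methyl(propargyl)amino on a saturated chain carbon, four bonds along the chain from an oxygen on an aromatic ring, gives a 1.6-fold lower number from compound 2 to compound 3 (0.19 log units; within the scatter) and so stays within the scatter. Within the data shown here, this is the first readable step at this position, and it shows that this change to the chain does not separate the two compounds. No evidence given here bears on this result. Still open, going by these compounds, is whether a longer chain, or dimethylamino in place of methyl(propargyl)amino, would move the number beyond the scatter.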